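This account rests on a few compounds, and the source may have more. Where it says the series, first, only, none or still open, it means among the compounds named here.

Measured so far in a functional assay on HEK293 cells for positive allosteric modulation of metabotropic glutamate receptor 5 (Rattus norvegicus), read by fluorescence and calcium flux; on this read-out higher numbers stand for larger maximal responses and lower numbers for smaller maximal responses:

Compound 1, `O=C(NCC1CC1)c1ccc(C#Cc2cccc(F)c2)cn1`: compound 1 gives 61.4%
Compound 2, `CC(C)(O)CCNC(=O)c1ccc(C#Cc2cccc(F)c2)cn1`: compound 2 gives 61.9%

Among these two numbers, compound 2 has the higher one, but the gap to compound 1 is small: the step of a number 0.5 percentage points higher from compound 1 to compound 2 (within the scatter) lies within the usual scatter of repeated measurements, so the two compounds cannot be told apart on this read-out.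

Compound 3, `CC1(CCNC(=O)c2ccc(C#Cc3cccc(F)c3)cn2)COC1`, has not yet been measured in this assay. It differs from compound 2 in one place: 3-methyloxetan-3-yl in place of 1-hydroxy-1-methylethyl on a saturated chain carbon, two bonds along the chain from an amide-type nitrogen. For the measured compounds named here, the only measured step that bears on this change is the one from compound 1 to compound 2, which also altered the tail attached to the amide-type nitrogen and left the maximal response essentially unchanged. With one tail change already leaving the number flat, the expectation for compound 3 is that the step of a number 0.9 percentage points lower from compound 2 to compound 3 (within the scatter) stays within the scatter, with no clear direction. Compound 3 is therefore estimated to give 61% in this assay, in a range from 49% to 73%.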

Compound 3, largest response reached (reported as efficacy), in percent of the reference or control that the assay uses: 65.7%
The estimate for compound 3 lay 4.7 percentage points below the measured number, and the stated range covers the measured number.
By their numbers in this assay, from the lowest: compounds 1, 2 and 3 (each within the scatter of the next).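

Exchanging 1-hydroxy-1-methylethyl for 3-methyloxetan-3-yl on a saturated chain carbon, two bonds along the chain from an amide-type nitrogen, removes the hydrogen-bond donor of the tail and brings in a four-membered non-aromatic ring, and in this assay this gives a number 3.8 percentage points higher from compound 2 to compound 3 (within the scatter) on the maximal response. Against the cyclopropyl tail, (3-methyloxetan-3-yl)methyl gives a number 4.3 percentage points higher from compound 1 to compound 3 (within the scatter) in the same read-out, so three different tails at this place, with or without that donor and with either ring or none, cannot be told apart in this assay by the largest response they reach. Nothing at hand explains why these tails read alike.

The compounds shown leave open whether any group at this place can move the maximal response beyond the scatter, for example a primary amine, a carboxylic acid or a longer alkyl chain. They also leave open whether the same flat picture would hold on a changed core, as all three compounds share one core.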